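The source may hold more compounds than are shown below. What is called first, only, known or untested is meant among the compounds shown, and "the series" means these compounds.

Compound 1 `Cc1ccc(C2=NN(c3ccc([N+](=O)[O-])cc3)C(c3cn(-c4ccccc4)nc3-c3ccc(Cl)c(Cl)c3)C2)cc1` gives the largest number here: in a functional assay on the whole organism (strain Wistar) for inhibition, with Rattus norvegicus as the target, read by paw edema, with a stated time of 30 min, at a dose of 50 mg/kg by the oral route (on this read-out higher numbers stand for more inhibition at the one dose given (going by the name of the read-out) and lower numbers for less inhibition), compound 1 reaches 57.4%, while compound 3 `O=[N+]([O-])c1ccc(N2N=C(c3ccc(F)cc3)CC2c2cn(-c3ccccc3)nc2-c2ccc(Cl)c(Cl)c2)cc1` gives 45.7% and compound 2 `Clc1ccc(C2=NNC(c3cn(-c4ccccc4)nc3-c3ccc(Cl)c(Cl)c3)C2)cc1` gives 33%. For the measured compounds named here, the one measured step, a number 11.7 percentage points lower from compound 1 to compound 3 (beyond the scatter), changes a group on a different part of the molecule and so says little about the change to compound 4 `Cc1ccc(C2=NN(C=O)C(c3cn(-c4ccccc4)nc3-c3ccc(Cl)c(Cl)c3)C2)cc1`, which is formyl in place of 4-nitrophenyl on an amine nitrogen in a ring. Compound 2, which carries a plain ring nitrogen with no large group and also a different substituent elsewhere, sits well below compound 1, and nothing measured shows what a formyl group alone does on that nitrogen. The expected direction is therefore downward, with a number 17.4 percentage points lower from compound 1 to compound 4 (beyond the scatter) as the estimated step, and compound 4 is expected to give about 40%, likely between 25% and 55%.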

Compound 4, a percentage reported as inhibition, in the whole organism at one dose (the size of the read-out at that dose, not a potency): 35.1%
Compound 4: middle estimate off by 4.9 percentage points, on the high side, and the stated range covers the measured number.
By their numbers in this assay, from the lowest: compounds 2 and 4 (each within the scatter of the next); then compound 3; then compound 1.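

Swapping 4-nitrophenyl for formyl on the amine nitrogen gives a number 22.3 percentage points lower from compound 1 to compound 4 (beyond the scatter) in this assay, the first step read at this nitrogen with the rest of the molecule unchanged. The position therefore matters to this read-out, and the larger aromatic group goes with the higher number in this one pair. Nothing measured here explains the difference. The compounds shown leave open whether the ring or the nitro group carries the difference. A plain phenyl, a 4-aminophenyl or an acetyl group on this nitrogen would help separate them.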